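A few compounds are considered here, and "the series" means these few. Any claim that something is new, unique, unknown or untested is made for them only; others in the source may bear on it.

Compound 1 `COc1cc(-c2nnc(SCC(=O)c3ccc(Br)cc3)n2N)cc(OC)c1OC` gives 10400 nM in a functional assay on HeLa cells (Homo sapiens) for antiproliferative activity, read by MTT assay, with a stated time of 48 h; a higher number here means a weaker inhibitor, a lower number a stronger inhibitor. Compound 2 `COc1cc(-c2nnc(SCC(=O)c3ccc(F)cc3)n2N)cc(OC)c1OC` gives 20900 nM in this assay, a shift of a 2.0-fold higher number from compound 1 to compound 2 (0.30 log units; within the scatter). Compound 3 `COc1cc(-c2nnc(SCC(=O)c3ccc(F)c(F)c3)n2N)cc(OC)c1OC` reaches only the limit of this assay and is reported as > 100000 nM. It thus stands at the limit of > 100000 nM in this assay, at which 1 of the 3 values shown sits. The steps of an at least 9.6-fold higher number from compound 1 to compound 3 (0.98 log units; beyond the scatter) and an at least 4.7-fold higher number from compound 2 to compound 3 (0.67 log units; beyond the scatter) are both beyond the scatter and leave compound 3 the weakest of the three. Compound 4 `COc1cc(-c2nnc(SCC(=O)c3ccccc3F)n2N)cc(OC)c1OC` differs from it by 2-fluorophenyl in place of 3,4-difluorophenyl on a carbonyl carbon. Among the compounds with values here, the change removes the fluoro whose addition gave an at least 4.7-fold higher number from compound 2 to compound 3 (0.67 log units; beyond the scatter), while the remaining fluorine moves to a place no measured compound shows, so a step back toward the numbers of compound 1 and compound 2 is expected but with wide uncertainty. For compound 4 the estimate is 30000 nM, between 8000 nM and 100000 nM, an expected step of an at least 3.3-fold lower number from compound 3 to compound 4 (0.52 log units; beyond the scatter).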

Compound 4, half-maximal inhibitory concentration: 80100 nM
The estimate for compound 4 lay 2.7-fold (0.43 log units) below the measured number; low and high end bracket the measured number.
By their numbers in this assay, from the lowest: compounds 1 and 2 (each within the scatter of the next); then compound 4. At a limit, above all of these: compound 3.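

In this assay, the site of a single fluoro on the ring at this carbonyl carbon matters: the 2-fluorophenyl group gives a 3.8-fold higher number from compound 2 to compound 4 (0.58 log units; beyond the scatter), and against the 4-bromophenyl group it gives a 7.7-fold higher number from compound 1 to compound 4 (0.89 log units; beyond the scatter). Having one fluoro rather than two therefore does not by itself return the numbers to those of compound 1 and compound 2. The step of an at least 1.2-fold lower number from compound 3 to compound 4 (0.09 log units; that floor lies within the scatter) does not separate the two compounds, and the value of compound 3 is a limit: the limit of > 100000 nM in this assay, at which 1 of the 4 values shown sits.

As far as these compounds go, the true size of that last step stays open. So does whether a 2-bromophenyl group, or an amine or a methoxy group on this ring, would follow compound 4.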